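Methyl on the indole nitrogen, carried to the selenium series

The source may report more compounds than this note shows. Statements on the series, on what has been measured and on what is new or still open speak of the compounds shown alone.

Measured in a functional assay on MHCC97H cells (Homo sapiens) for antiproliferative activity, read by MTT assay, with a stated time of 48 h; a higher number here means a weaker inhibitor, a lower number a stronger inhibitor:
compound 1, `COc1ccc2c(/C=C/C(=O)c3cc(N)c(OC)c(OC)c3)c[nH]c2c1`, gives 186 nM
compound 2, `COc1ccc2c(/C=C/C(=O)c3cc(N)c(OC)c(OC)c3)cn(C)c2c1`, gives 198 nM
compound 3, `COc1cc(C(=O)/C(C)=C/c2c[nH]c3ccccc23)cc([Se]C)c1OC`, gives 18 nM

Compound 1 and compound 2 share one core and differ only by methyl in place of hydrogen on an aromatic nitrogen. The step that this change made is a 1.1-fold higher number from compound 1 to compound 2 (0.03 log units; within the scatter), so the two values are to be read as the same within the usual spread of the measurement.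

Compound 3 has the lowest of the three values, and its gaps to compound 1 and to compound 2 both lie beyond the scatter. The difference between the core of compound 3 and the core of compound 1 is not broken down here.

Compound 4, `COc1cc(C(=O)/C(C)=C/c2cn(C)c3ccccc23)cc([Se]C)c1OC`, has not yet been measured in this assay. It differs from compound 3 by methyl in place of hydrogen on an aromatic nitrogen. This is the same change, at the same kind of place, as the one made from compound 1 to compound 2, and among the compounds shown it occurs twice in all.

The expected step is a 1.2-fold higher number from compound 3 to compound 4 (0.07 log units; within the scatter), resting on the measured pair, because a 1.1-fold higher number from compound 1 to compound 2 (0.03 log units; within the scatter) was within the scatter and nothing among the shown compounds points to a different outcome on the core of compound 3. Compound 4 is therefore expected to give about 21 nM in this assay. The expected range for compound 4 runs from 9 nM to 50 nM.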

Compound 4, half-maximal inhibitory concentration: 26 nM
Beside the measured number, compound 4's estimate is 1.2-fold (0.09 log units) below it; measured number inside the range.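

In this assay, methyl in place of hydrogen on an aromatic nitrogen gives a 1.4-fold higher number from compound 3 to compound 4 (0.16 log units; within the scatter), so on the core of compound 3 the change leaves the value unmoved within the usual spread of the measurement. The change therefore carries over between the two cores shown, with the same outcome on each and no readable difference between the two steps: the same change on two cores in this assay, a 1.1-fold higher number (0.03 log units; within the scatter) from compound 1 to compound 2 and a 1.4-fold higher number (0.16 log units; within the scatter) from compound 3 to compound 4, 1.4-fold (0.13 log units) apart, within the scatter of two such steps This holds for two cores and one assay only: it does not show that the same step would be seen on a third core or in another cell line, and it gives no reason why the nitrogen accepts methyl on either core.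

The compounds shown leave open whether ethyl, a longer chain, or a chain ending in an amine or a carboxylic acid on that aromatic nitrogen would also leave the value unmoved. Also open is which of the places where the core of compound 1 and the core of compound 3 differ accounts for the gap between their values, as no pair shown changes one of those places alone.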